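This account rests on a few compounds, and the source may have more. Where it says the series, first, only, none or still open, it means among the compounds named here.

Measured so far:
compound 1 `CCCCSc1nc(N)nc2c1ncn2/C=C1/CC1(CO)CO` — > 20000 nM
compound 2 `Nc1nc(OCC(F)(F)F)c2ncn(/C=C3/CC3(CO)CO)c2n1` — > 20000 nM

In an ADME assay on MOLT-3 cells (Homo sapiens) for cytotoxicity, with a stated time of 7 days (a lower number here means that less compound is tolerated, a higher number that more compound is tolerated), compound 1 gives > 20000 nM, which is a limit of the assay and not a number. In this assay compound 2 gives > 20000 nM, again a limit of the assay and not a number. Within the data shown here, compound 2 thus stands at the edge of what this assay reports; it cannot be ranked against compound 1, and the only step between measured compounds, a step that the two limits leave unreadable from compound 1 to compound 2, has no readable size, since (the limit of > 20000 nM in this assay, at which 2 of the 2 values shown sit).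

The unmeasured compound is compound 3 `CCOc1nc(N)nc2c1ncn2/C=C1/CC1(CO)CO`. The change from compound 2 to compound 3 is methyl in place of trifluoromethyl on a saturated chain carbon bound to an oxygen on an aromatic ring. Among the measured compounds shown here, the one measured step that bears on a change at this position is the step from compound 1 to compound 2, and it is unreadable; both measured values sit at the limit of this assay. For the measured compounds named here, no measured step points toward a concentration this assay could resolve, so no step beyond the scatter is expected, and the expected step that the limit leaves unreadable from compound 2 to compound 3 is taken as nil. Compound 3 is therefore expected at 30000 nM in this assay, within 15000 nM to 100000 nM, most likely reported again only as a limit.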

Compound 3, half-maximal cytotoxic concentration: > 20000 nM
Compound 3: only a limit was reported; the forecaster's own chance of this, stated with the estimate: 85%; the middle value is on the limit's open side.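

Compound 1, compound 2 and compound 3 all give a limit of the assay and not a number in this assay, so no step among them can be read: the limit of > 20000 nM in this assay, at which 3 of the 3 values shown sit.

The compounds shown leave open whether any group at this place on the shared core gives a cytotoxic concentration readable as a number, and how butylsulfanyl, 2,2,2-trifluoroethoxy and ethoxy rank.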